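Hydroxy for Cyano on an Inactive Piperazine Series

The source may report more compounds than this note shows. Statements on the series, on what has been measured and on what is new or still open speak of the compounds shown alone.

Compound 1 `COC(=O)CC/C(C)=C/Cc1c(OC)c(C)c2c(c1OCC#CCN1CCCc3ccccc31)C(=O)OC2` was tested in a functional assay on MDA-MB-231 cells (Homo sapiens) for inhibition, read by sulforhodamine B assay; on this read-out lower numbers stand for stronger inhibition and higher numbers for weaker inhibition. In this assay compound 1 reaches only the assay limit of > 50000 nM. Compound 3 `COC(=O)CC/C(C)=C/Cc1c(OC)c(C)c2c(c1OCC#CCN1CCC(Cc3ccccc3)CC1)C(=O)OC2` likewise reaches only the limit, giving > 50000 nM. Compound 2 `COC(=O)CC/C(C)=C/Cc1c(OC)c(C)c2c(c1OCC#CCN1CCN(c3ccc(C#N)cc3)CC1)C(=O)OC2` also gives only the limit of > 50000 nM in this assay, so its standing among the measured compounds is that of the limit of > 50000 nM in this assay, at which 3 of the 3 values shown sit; no number separates it from the others. Compound 4 `COC(=O)CC/C(C)=C/Cc1c(OC)c(C)c2c(c1OCC#CCN1CCN(c3ccc(O)cc3)CC1)C(=O)OC2` carries the change (hydroxy in place of cyano on an aromatic carbon). Within the data shown here, no measured step exists here to set a size for such a change, so the writer expects the step that the limit leaves unreadable from compound 2 to compound 4 to remain within the scatter. Compound 4 is therefore estimated at 60000 nM, within 20000 nM to 200000 nM, most likely again reported as a limit.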

Compound 4, half-maximal inhibitory concentration: > 50000 nM
Compound 4: only a limit was reported (the forecaster's own chance of this, stated with the estimate: 80%); the middle value does not contradict the limit.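

Among these compounds, compound 2 and compound 4 both give only a limit, so no step between them can be read: the limit of > 50000 nM in this assay, at which 4 of the 4 values shown sit. The compounds shown leave open how hydroxy and cyano compare, and whether any of these compounds reaches a measurable inhibition.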